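The source may hold more compounds than are shown below. What is called first, only, known or untested is meant among the compounds shown, and "the series" means these compounds.

Working notes on the series. Compound 1 `O=C(Nc1cccc(C(F)(F)F)c1)n1ccc2cc(Oc3ncnc4c3CNCC4)ccc21` and compound 2 `CC(C)c1cc(NC(=O)n2ccc3cc(Oc4ncnc5c4CCNC5)ccc32)n[nH]1` were run in a functional assay on the whole organism (strain C57BL/6) for inhibition, with Mus musculus as the target, read by microscopy, with a stated time of 6 days, at a dose of 10 mg/kg by the oral route; on this read-out higher numbers stand for more inhibition at the one dose given (going by the name of the read-out) and lower numbers for less inhibition. In this assay compound 1 gives 0%. Compound 2 gives 0% in this assay. Compound 2 thus stands level with compound 1 at the digits reported, and the two differ by nothing beyond the usual scatter, so no ordering between them can be read from these numbers.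

Compound 3 `CC(C)(C)c1cc(NC(=O)n2ccc3cc(Oc4ncnc5c4CCNC5)ccc32)no1` is not yet measured. It differs from compound 2 in one place: 5-(tert-butyl)-1,2-oxazol-3-yl in place of 5-isopropyl-1H-pyrazol-3-yl on an amide-type nitrogen. Within the data shown here, nothing measured here shows what such an exchange does in this assay, and no step between measured compounds is available to lean on. The step from compound 2 to compound 3 in this assay is expected to be no change at the digits printed from compound 2 to compound 3 (within the scatter), that is, none beyond the scatter. For compound 3 the estimate in this assay is 0%, with a range from 0% to 15%.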

Compound 3, a percentage reported as inhibition, in the whole organism at one dose (the size of the read-out at that dose, not a potency): 83%
Compound 3: middle estimate off by 83 percentage points, on the low side; measured number outside the range, above it.
By their numbers in this assay, from the lowest: compounds 1 and 2 (each within the scatter of the next); then compound 3.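

The group on the amide-type nitrogen is a place where the read-out can move strongly: with the rest of the structure unchanged, 5-(tert-butyl)-1,2-oxazol-3-yl in place of 5-isopropyl-1H-pyrazol-3-yl gives a number 83 percentage points higher from compound 2 to compound 3 (beyond the scatter) in this assay. The exchange changes the ring hetero atoms, the hydrogen-bond donor and acceptor counts and the alkyl group together, so the step belongs to the group as a whole and cannot be divided among these parts. No measurement at hand bears on what lies behind the step.

The compounds shown leave open whether the ring or the alkyl group carries the step, which a 5-(tert-butyl)-1H-pyrazol-3-yl group would help to separate. They also leave open how a cyclopropyl group or an amine in place of the tert-butyl would read in this assay.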